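The source may hold more compounds than are shown below. What is called first, only, known or untested is meant among the compounds shown, and "the series" means these compounds.

In a functional assay on HOS-TE85 cells (Homo sapiens) for inhibition, read by CCK-8 assay, with a stated time of 72 h (on this read-out lower numbers stand for stronger inhibition and higher numbers for weaker inhibition), compound 1 (`O=C(NCCCCc1ccccc1)c1cccc(C2SCC(=O)N2c2cnccn2)c1`) gives > 1000 nM, which is a limit and not a number. Within the data shown here, compound 2 (`C#Cc1cc(C(=O)NCCCCc2ccccc2)cc(C2SCC(=O)N2c2ccccc2OC)c1`) gives 40.8 nM, the only true number so far. Compound 3 (`O=C(NCCCCc1ccccc1)c1cccc(C2SCC(=O)N2c2ccccc2)c1`) has phenyl in place of pyrazin-2-yl on an amide-type nitrogen in a ring. In this assay, a shift toward stronger inhibition is expected, resting on compound 2 at 40.8 nM, which also carries a carbon-only aromatic ring on that nitrogen. The expected change is an at least 3.3-fold lower number from compound 1 to compound 3 (0.52 log units; beyond the scatter). For compound 3 the estimate is 300 nM, with an expected range of 80 nM to 1000 nM.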

Compound 3, half-maximal inhibitory concentration: 15.9 nM
Estimate against measurement, compound 3: 19-fold (1.28 log units) above, outside the stated range (below it).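

Among these compounds, on the amide-type nitrogen in a ring, phenyl in place of pyrazin-2-yl gives an at least 62-fold lower number from compound 1 to compound 3 (1.79 log units; beyond the scatter) in this assay, the first comparison that differs in one place. At this position, the ring that leaves and the ring that enters have the same heavy-atom count, yet the read-out separates them clearly. Compound 1 stands at a limit and not at a number, so the step gives only a minimum size: the limit of > 1000 nM in this assay, at which 1 of the 3 values shown sits.

Going by these compounds, whether a pyridin-2-yl group on that nitrogen stays close to phenyl remains open. Compound 2 differs from compound 3 in more than one place, so its methoxy and ethynyl groups cannot be weighed separately.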